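Swapping the halogenated phenyl on a tetrazole amide series

The compounds below may be only part of what the source reports. "The series", "measured", "known", "first", "only" and "open" are said of these compounds alone.

In an assay on HEK293 cells for activation of Kir3.1/Kir3.2 (Homo sapiens), read by thallium flux (a higher number here means a larger maximal response, a lower number a smaller maximal response), compound 3 `Cc1cc(NC(=O)Cn2nnc(-c3cc(Cl)cc(Cl)c3)n2)n(C2CCCCC2)n1` gives 82%, the lowest of the three numbers shown, though the gap to compound 2 `Cc1cc(NC(=O)Cn2nnc(-c3cccc(Cl)c3)n2)n(C2CCCCC2)n1` at 89% and to compound 1 `Cc1cc(NC(=O)Cn2nnc(-c3ccccc3)n2)n(C2CCCCC2)n1` at 92% stays within the scatter. Compound 4 `Cc1cc(NC(=O)Cn2nnc(-c3ccccc3F)n2)n(C2CCCCC2)n1` differs from compound 3 by 2-fluorophenyl in place of 3,5-dichlorophenyl on an aromatic carbon. The measured steps that bear on this are a number 3 percentage points lower from compound 1 to compound 2 (within the scatter), a number 7 percentage points lower from compound 2 to compound 3 (within the scatter) and a number 10 percentage points lower from compound 1 to compound 3 (within the scatter); none moved the maximal response beyond the scatter, so changing the halogen pattern on the phenyl has so far left the response essentially unchanged. Compound 4 is therefore expected to show no step beyond the scatter, a number 7 percentage points higher from compound 3 to compound 4 (within the scatter). The estimate for compound 4 in this assay is 89%, within a range of 77% to 100%.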

Compound 4, largest response reached (Emax), in percent of the reference or control that the assay uses: 88%
Beside the measured number, compound 4's estimate is 1 percentage points above it; measured number inside the range.
By their numbers in this assay, from the lowest: compounds 3, 4, 2 and 1 (each within the scatter of the next).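

In this assay, 2-fluorophenyl brings a different halogen and a different substitution pattern to this aromatic carbon, yet the maximal response stays in the same range as with the other aryl groups (a number 4 percentage points lower from compound 1 to compound 4 (within the scatter)), (a number 1 percentage points lower from compound 2 to compound 4 (within the scatter)) and (a number 6 percentage points higher from compound 3 to compound 4 (within the scatter)). So far, this position has tolerated each of these halogen changes on the phenyl without a step beyond the scatter. No supporting evidence bears on why the response stays flat. The compounds shown all carry only hydrogen, chloro or fluoro on the phenyl. On these data alone, whether an amine, a methoxy group or a carboxylic acid there would shift the response remains open, as does any replacement of the phenyl itself.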